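Shortening the side chain of compound 3

A few compounds are considered here, and "the series" means these few. Any claim that something is new, unique, unknown or untested is made for them only; others in the source may bear on it.

Of the compounds shown here, three of one family have been measured in a functional assay on HBL-100 cells (Homo sapiens) for antiproliferative activity, read by sulforhodamine B assay, with a stated time of 48 h; on this read-out lower numbers stand for stronger inhibition of growth and higher numbers for weaker inhibition of growth. Compound 1, `CC(C)C(C#CC(=O)OC(C)(C)C)O/C=C/C(=O)OC(C)(C)C`, gives 3000 nM in this assay. Compound 2, `COC(=O)C#CC(C[C@@H](C)CCC=C(C)C)O/C=C/C(=O)OC`, gives 3100 nM. Compound 3, `CCCCCC(C#CC(=O)OC)O/C=C/C(=O)OC`, gives 1900 nM; the gaps from compound 3 to compound 1 and to compound 2 both lie within the scatter of the method, so the three compounds cannot be told apart on these numbers. Across the set, the group attached to the saturated chain carbon varies widely, from a branched group in compound 1 to a long branched chain in compound 2 and a straight chain in compound 3, without any shift that rises above the scatter.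

Compound 4, `CCC(C#CC(=O)OC)O/C=C/C(=O)OC`, has not yet been measured. It differs from compound 3 in one place: hydrogen in place of propyl on a saturated chain carbon, three bonds along the chain from an oxygen on an unsaturated carbon and a triple-bonded carbon. Given that the wider changes at the same carbon among compound 1, compound 2 and compound 3 left the numbers within the scatter of one another, compound 4 is expected to behave much like compound 3, with an estimated step of a 1.3-fold higher number from compound 3 to compound 4 (0.12 log units; within the scatter) that stays within the scatter. On that basis compound 4 is estimated at 2500 nM in this assay, with a range from 1000 nM to 6500 nM.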

Compound 4, concentration for 50% growth inhibition: 320 nM
For compound 4 the middle estimate is 7.8-fold (0.89 log units) above the measured one; measured number below the stated range.
By their numbers in this assay, from the lowest: compound 4; then compounds 3, 1 and 2 (each within the scatter of the next).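

In this assay, for the compounds shown here, the replacement of propyl by hydrogen on a saturated chain carbon, three bonds along the chain from an oxygen on an unsaturated carbon and a triple-bonded carbon, gives a 5.9-fold lower number from compound 3 to compound 4 (0.77 log units; beyond the scatter) and so provides the first step in this family that can be tied to a single place. The earlier compounds shown here differ from one another in more than one place, so their closely grouped numbers could not show how this chain alone affects growth inhibition; this pair shows that, with the rest of the structure unchanged, going from pentyl to ethyl lowers the number beyond the scatter. Nothing measured here speaks to the reason for this step.

From the compounds shown here alone, this is a single pair, so it remains open whether the number changes steadily with chain length or whether ethyl is a special case, a question that methyl, propyl or butyl at the same carbon would address. Going by these compounds, it is also open whether this gain would persist with a hydroxyl group or an amine on the short chain, or with a cyclopropyl group in its place.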